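The source may hold more compounds than are shown below. What is called first, only, known or untested is meant among the compounds shown, and "the series" means these compounds.

Measured so far:
compound 1 `COc1ccc2nc(Nc3ccnc(Nc4ccc(S(N)(=O)=O)cc4)n3)sc2c1` — 6240 nM
compound 2 `Cc1ccc2nc(Nc3ccnc(Nc4ccc(S(N)(=O)=O)cc4)n3)sc2c1` — 3870 nM

In a functional assay on MDA-MB-231 cells (Homo sapiens) for antiproliferative activity, read by MTT assay, with a stated time of 48 h (a lower number here means a stronger inhibitor, a higher number a weaker inhibitor), compound 1 gives 6240 nM, the highest of the two numbers in hand. Compound 2 gives 3870 nM; the step of a 1.6-fold lower number from compound 1 to compound 2 (0.21 log units; within the scatter) lies within the scatter, so the two are not separated by this assay.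

Compound 3 `COc1ccc2nc(Nc3nc(Nc4ccc(S(N)(=O)=O)cc4)ncc3F)sc2c1` is not yet measured. It differs from compound 1 by fluoro in place of hydrogen on an aromatic carbon, the new group sitting on an aromatic carbon of a six-membered aromatic ring with 2 nitrogen. Within the data shown here, no measured step bears directly on this change: the single step available, a 1.6-fold lower number from compound 1 to compound 2 (0.21 log units; within the scatter), concerns methyl in place of methoxy on the other end of the shared core and was itself within the scatter. The series therefore gives no basis to expect a step beyond the scatter in this assay; the expected step is a 1.2-fold lower number from compound 1 to compound 3 (0.10 log units; within the scatter), with a wide range to reflect the lack of a precedent. Compound 3 is estimated at 5000 nM, between 1800 nM and 14000 nM.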

Compound 3, half-maximal inhibitory concentration: 26600 nM
The estimate for compound 3 lay 5.3-fold (0.73 log units) below the measured number; the measured number lies above the stated range.
By their numbers in this assay, from the lowest: compounds 2 and 1 (each within the scatter of the next); then compound 3.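

In this assay, among these compounds, fluoro in place of hydrogen on an aromatic carbon of the six-membered aromatic ring with 2 nitrogen gives a 4.3-fold higher number from compound 1 to compound 3 (0.63 log units; beyond the scatter) and is the first step to pass the scatter. This position, ortho to a large group and para to a large group, is therefore sensitive to a change of a single heavy atom, whereas methyl in place of methoxy gave only a 1.6-fold lower number from compound 1 to compound 2 (0.21 log units; within the scatter) and left its pair unseparated. No measurement available here accounts for the rise in the number.

Going by these compounds, it remains open whether the same fluoro change raises the number on compound 2, where the methoxy is replaced by methyl. On these data alone, it is also open whether chloro, methyl or an amine on this carbon would follow fluoro or leave the number near that of compound 1.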